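Swapping the chloro position on a thioether benzyl group

This account rests on a few compounds, and the source may have more. Where it says the series, first, only, none or still open, it means among the compounds named here.

Compound 1 `COc1ccc(C2N=C(SCc3ccccc3Cl)NC(C)=C2C(=O)Nc2ccc(F)cc2)cc1OC` gives 25.3% in a functional assay on the whole organism (artery, strain albino) with Rattus norvegicus as the target, with a stated time of 180 min, at a dose of 10 mg/kg by the oral route; a higher number here means more inhibition at the dose given (going by the name of the read-out), a lower number less inhibition. Compound 2 `COc1ccc(C2N=C(SCc3cccc(Cl)c3)NC(C)=C2C(=O)Nc2ccc(F)cc2)cc1OC` gives 13.4% in this assay. The only difference between them is 3-chlorophenyl in place of 2-chlorophenyl on a saturated chain carbon bound to a sulfur, and that change gave a number 11.9 percentage points lower from compound 1 to compound 2 (beyond the scatter). Compound 3 `CC1=C(C(=O)Nc2ccc(Br)cc2)C(c2ccc(Cl)cc2Cl)N=C(SCc2ccccc2Cl)N1` gives 22.2% in this assay, a value within the scatter of that of compound 1; the difference between the cores of compound 3 and compound 1 is not broken down here. Compound 4 `CC1=C(C(=O)Nc2ccc(Br)cc2)C(c2ccc(Cl)cc2Cl)N=C(SCc2cccc(Cl)c2)N1` has not been measured. It differs from compound 3 by 3-chlorophenyl in place of 2-chlorophenyl on a saturated chain carbon bound to a sulfur, the same change as between compound 1 and compound 2. Going by the values given here, for compound 4 a step of about a number 11.2 percentage points lower from compound 3 to compound 4 (beyond the scatter) is expected because a number 11.9 percentage points lower from compound 1 to compound 2 (beyond the scatter) was seen for the same change, though only one such pair is known. Compound 4 is therefore estimated at 11%, with a range of 2% to 21%.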

Compound 4, a percentage reported as inhibition, in the whole organism at one dose (the size of the read-out at that dose, not a potency): 11.9%
Beside the measured number, compound 4's estimate is 0.9 percentage points below it; low and high end bracket the measured number.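

In this assay, the swap from 2-chlorobenzyl to 3-chlorobenzyl gives a number 10.3 percentage points lower from compound 3 to compound 4 (beyond the scatter) on the core of compound 3. Set beside the earlier step, the change carries over from one core to the other at much the same size: the same change on two cores in this assay, a number 11.9 percentage points lower (beyond the scatter) from compound 1 to compound 2 and a number 10.3 percentage points lower (beyond the scatter) from compound 3 to compound 4, 1.6 percentage points apart, within the scatter of two such steps. Going by these compounds alone, this rests on only two pairs of compounds, so it shows agreement on these two cores alone and does not show that other cores would follow or why the swap lowers the number.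

Only 2-chlorobenzyl and 3-chlorobenzyl appear on the sulfur in the compounds shown. Going by these compounds, it stays open how 4-chlorobenzyl, a plain benzyl group or a longer chain such as phenethyl would behave there.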